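Swapping Dimethylphenyl for Dimethoxyphenyl on a Shared Core

The source may hold more compounds than are shown below. What is called first, only, known or untested is meant among the compounds shown, and "the series" means these compounds.

Two compounds share one core and differ only in the group carried on a nitrogen on an aromatic ring. Compound 1 `Cc1n[nH]c2ccc(-c3nc4cnc(N5CCN(C)CC5)cn4c3Nc3ccc(Br)cc3)cc12` carries one such group, and in a functional assay on CWR22R cells (Homo sapiens) for inhibition, with a stated time of 120 h, tested at 10 uM (a higher number here means more inhibition at the concentration tested (going by the name of the read-out), a lower number less inhibition), compound 1 gives 11.7%, a modest effect at the concentration tested. Compound 2 `Cc1ccc(C)c(Nc2c(-c3ccc4[nH]nc(C)c4c3)nc3cnc(N4CCN(C)CC4)cn23)c1` carries a 2,5-dimethylphenyl group in that place; in this assay compound 2 has "not determined" (no result reported), so no number stands for it and it cannot be placed against compound 1. Compound 3 `COc1ccc(Nc2c(-c3ccc4[nH]nc(C)c4c3)nc3cnc(N4CCN(C)CC4)cn23)cc1OC` has not been measured; it differs from compound 2 by 3,4-dimethoxyphenyl in place of 2,5-dimethylphenyl on a nitrogen on an aromatic ring.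

Going by the values given here, no step between two measured compounds is known here, so the size of this change in this assay cannot be read from any pair. The step from compound 2 to compound 3 is expected to be small, within the usual scatter, with no direction that the data favour. Compound 3 is therefore estimated at 15%, within a range from 0% to 45%, resting mainly on the fact that compound 1 gives 11.7% and is the only measured anchor.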

Compound 3, a percentage reported as inhibition, at one concentration (the size of the read-out at that concentration, not a potency): 0%
For compound 3 the middle estimate is 15 percentage points above the measured one; the measured number falls inside the stated range.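

In this assay, the group on a nitrogen on an aromatic ring now has its first readable step: 3,4-dimethoxyphenyl in place of 4-bromophenyl gives a number 11.7 percentage points lower from compound 1 to compound 3 (beyond the scatter). This shows that inhibition at the concentration tested does respond to what this position carries, even though the effect of compound 1 was modest to begin with; compound 3, at 0%, shows that the shared core with 3,4-dimethoxyphenyl in this place leaves no inhibition to read. Nothing available explains why the two groups differ in this way.

The step from compound 2 to compound 3 cannot be read, as compound 2 has no reported result, so 2,5-dimethylphenyl remains unplaced against both other groups. Also open, going by these compounds, is whether the loss follows from removing the bromine or from adding the two methoxy groups, a question that an unsubstituted phenyl or a 4-methoxyphenyl group in the same place could help to separate, and how a group of another kind, such as a pyridine ring or a cyclohexyl ring, would fare there.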